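The compounds below may be only part of what the source reports. "The series", "measured", "known", "first", "only" and "open" are said of these compounds alone.

Compound 1 `O=C1O[C@@H](CN2CCCCC2)CN1c1ccc(-n2cc(-c3ccccn3)cn2)c(F)c1` was tested in an ADME assay on L02 cells (Homo sapiens) for cytotoxicity, read by MTT assay, with a stated time of 48 h (a higher number here means a weaker inhibitor, a lower number a stronger inhibitor), where compound 1 gives only a limit, > 400 ug/mL. Compound 2 `O=C1O[C@@H](CN2CCC(O)CC2)CN1c1ccc(-n2cc(-c3ccccn3)cn2)c(F)c1` likewise gives only a limit in this assay, namely > 400 ug/mL. The step that the two limits leave unreadable from compound 1 to compound 2 therefore cannot be read. Both measured values sit at the limit of > 400 ug/mL in this assay, at which 2 of the 2 values shown sit. Compound 3 `O=C1O[C@@H](CN2CCC(c3ccc(F)cc3)CC2)CN1c1ccc(-n2cc(-c3ccccn3)cn2)c(F)c1` carries 4-fluorophenyl in place of hydroxy on a saturated ring carbon. Among the measured compounds shown here, no measured step has a readable size, so the earlier numbers give no direction beyond the scatter for this change. For compound 3 the expected step is an at least 1.6-fold lower number from compound 2 to compound 3 (0.20 log units; that floor lies within the scatter). Compound 3 is estimated at 250 ug/mL, expected to fall within 60 ug/mL to 400 ug/mL.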

Compound 3, half-maximal inhibitory concentration: > 400 ug/mL
Compound 3 gave a limit, no number (the forecaster's own chance of this, stated with the estimate: 50%); at least 1.6-fold (0.20 log units) between middle value and limit.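

Compound 1, compound 2 and compound 3 all give only limits, so no step among them can be read: the limit of > 400 ug/mL in this assay, at which 3 of the 3 values shown sit.

How far any of these compounds lies beyond that limit in this assay, and whether the changes on the saturated ring alter it, stays open.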